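The source may hold more compounds than are shown below. What is called first, only, known or untested is meant among the compounds shown, and "the series" means these compounds.

Measured so far: compound 1 `Cc1ccc(CSC[C@@H](NC(=O)[C@@H](CS)Cc2cccc3ccccc23)C(=O)O)cc1` gives 2 nM; compound 2 `O=C(N[C@H](CSCc1ccccc1)C(=O)O)[C@@H](CS)Cc1ccc(Cl)cc1` gives 3 nM.

In an assay on isolated protein for inhibition of Neprilysin (Oryctolagus cuniculus) (on this read-out higher numbers stand for weaker inhibition and lower numbers for stronger inhibition), compound 1 gives 2 nM, the lower of the two numbers recorded, while compound 2 gives 3 nM, a gap that lies within the scatter, so neither can be called the stronger inhibitor. Compound 3 `Cc1ccc(CSC[C@@H](NC(=O)[C@H](CS)Cc2cccc3ccccc23)C(=O)O)cc1` differs from compound 1 in this way: the two compounds have the same atoms and bonds and differ only in configuration as drawn: 1 of 2 stereo elements differ; a stereocentre at a saturated chain carbon is drawn S in compound 1 and R in compound 3. Within the data shown here, no measured pair shows what such an inversion of configuration does in this assay, so the size of the step is uncertain. Compound 3 is estimated at 20 nM, in the range 3 nM to 150 nM, which means an expected step of a 10-fold higher number from compound 1 to compound 3 (1.00 log units; beyond the scatter) toward weaker inhibition, beyond the scatter.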

Compound 3, half-maximal inhibitory concentration: 39 nM
Compound 3: the middle estimate sits 2.0-fold (0.29 log units) below what was measured, and the stated range covers the measured number.
By their numbers in this assay, from the lowest: compounds 1 and 2 (each within the scatter of the next); then compound 3.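

In this assay, inverting this one stereocentre gives a 20-fold higher number from compound 1 to compound 3 (1.29 log units; beyond the scatter), so the configuration at this saturated chain carbon matters on this read-out, which the earlier pair could not reveal. The step can be assigned to that inversion alone because of one structural fact: the fact that compounds 1 and 3 differ only in the configuration as drawn

The compounds shown leave open whether the second stereocentre is equally sensitive to inversion. They also leave open whether this step keeps its size when a hydroxamic acid replaces the thiol.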